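Removing a Ring Hydroxy Group from a Thioester Imide

The source may report more compounds than this note shows. Statements on the series, on what has been measured and on what is new or still open speak of the compounds shown alone.

Of the compounds shown here, three have been measured in a functional assay on RAW264.7 cells (Mus musculus) for inhibition, read by Griess assay, with a stated time of 24 h; on this read-out higher numbers stand for weaker inhibition and lower numbers for stronger inhibition. Compound 1, `CC(=O)S[C@]12CC[C@H](O)[C@H]1C(=O)NC2=O`, gives 833000 nM in this assay. Compound 2, `CC(=O)S[C@]12CCC[C@H]1C(=O)NC2=O`, differs from compound 1 only in that hydrogen replaces the hydroxy group on a saturated ring carbon, a change described as hydrogen in place of hydroxy on a saturated ring carbon; in this assay compound 2 gives 59200 nM, which is a 14-fold lower number from compound 1 to compound 2 (1.15 log units; beyond the scatter). Compound 3, `O=C(S[C@]12CC[C@H](O)[C@H]1C(=O)NC2=O)c1ccccc1Cl`, carries a 2-chlorophenyl group in place of the methyl on the carbonyl carbon, described as 2-chlorophenyl in place of methyl on a carbonyl carbon; in this assay compound 3 gives 178000 nM, which is a 4.7-fold lower number from compound 1 to compound 3 (0.67 log units; beyond the scatter). Among the three numbers, that of compound 3 is the second highest: compound 2 stands below it and compound 1 above it, both differences beyond the scatter.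

Compound 4, `O=C(S[C@]12CCC[C@H]1C(=O)NC2=O)c1ccccc1Cl`, has not yet been measured. It differs from compound 3 by hydrogen in place of hydroxy on a saturated ring carbon. Among the measured compounds shown here, this is the same kind of change as the one from compound 1 to compound 2, though the surroundings differ: in compound 1 the changed carbon is two ring bonds from the ring atom that bears an acetylsulfanyl group, while in compound 3 it is two ring bonds from the ring atom that bears a large group. The two cores differ by 2-chlorophenyl in place of methyl on a carbonyl carbon. If the earlier step carries over, compound 4 is expected to show a 12-fold lower number from compound 3 to compound 4 (1.07 log units; beyond the scatter), because the step of a 14-fold lower number from compound 1 to compound 2 (1.15 log units; beyond the scatter) was large. Allowing some uncertainty since the change has been seen only once, compound 4 is estimated at 15000 nM, between 4000 nM and 60000 nM.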

Compound 4, half-maximal inhibitory concentration: 59800 nM
Compound 4: the middle estimate sits 4.0-fold (0.60 log units) below what was measured; measured number inside the range.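

In this assay, hydrogen in place of hydroxy on a saturated ring carbon again gives stronger inhibition, with a 3.0-fold lower number from compound 3 to compound 4 (0.47 log units; beyond the scatter) on the core that carries the 2-chlorophenyl group, so the direction of the change holds on both cores shown. The size of the step does not carry over, and the two steps clearly differ: the same change on two cores in this assay, a 14-fold lower number (1.15 log units; beyond the scatter) from compound 1 to compound 2 and a 3.0-fold lower number (0.47 log units; beyond the scatter) from compound 3 to compound 4, 4.7-fold (0.67 log units) apart, beyond the scatter of two such steps. Two cores are too few to show why the size differs or how large the step would be on a further core, although the numbers do show that compound 2 at 59200 nM and compound 4 at 59800 nM stand almost level once the hydroxy group has gone.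

The compounds shown leave open what other groups on the saturated ring carbon would do, such as a methoxy group or an amine in place of the hydroxy group. They also leave open whether the gap between the two steps would persist with other groups on the carbonyl carbon, such as a longer chain in place of methyl or 2-chlorophenyl.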